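Phenyl to propyl on the amine chain of compound 2

This account rests on a few compounds, and the source may have more. Where it says the series, first, only, none or still open, it means among the compounds named here.

Compound 2 `CC1(C)CC(=O)c2cc(C#N)c(NCc3ccccc3)nc2C1` is the benzylamine of the set. In an in vitro functional assay on cells for antagonist activity at metabotropic glutamate receptor 1 (Rattus norvegicus), read by inositol phosphate accumulation (on this read-out higher numbers stand for weaker inhibition and lower numbers for stronger inhibition), compound 2 gives 2500 nM, the lowest of the two numbers recorded there. Among the measured compounds shown here, compound 3 `CN(Cc1ccccc1)c1nc2c(cc1C#N)C(=O)CC(C)(C)C2` carries methyl in place of hydrogen on a nitrogen on an aromatic ring and gives 5300 nM in this assay; the step of a 2.1-fold higher number from compound 2 to compound 3 (0.33 log units; beyond the scatter) is the only measured step. Compound 1 `CC1(C)CC(=O)c2cc(C#N)c(N3CC=C(c4ccccc4)CC3)nc2C1` gives < 1000 nM in this assay, which is a limit of the assay and not a number (the limit of < 1000 nM in this assay, at which 1 of the 3 values shown sits).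

Compound 4 `CCCCNc1nc2c(cc1C#N)C(=O)CC(C)(C)C2` differs from compound 2 by propyl in place of phenyl on a saturated chain carbon bound to a nitrogen on an aromatic ring. For the measured compounds named here, no measured step touches this part of the molecule: the one step known alters the nitrogen substituent, not the group on the chain carbon, so it gives no direct guide. Going by the values given here, every compound measured so far, whether as a number or as a limit, keeps the phenyl. Compound 4 is therefore expected to give 8000 nM (range 2500 nM to 25000 nM) in this assay. The expected step of a 3.2-fold higher number from compound 2 to compound 4 (0.51 log units; beyond the scatter) points toward a higher number, beyond the scatter.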

Compound 4, half-maximal inhibitory concentration: 1700 nM
Compound 4: the middle estimate sits 4.7-fold (0.67 log units) above what was measured; measured number below the stated range.
By their numbers in this assay, from the lowest: compounds 4 and 2 (each within the scatter of the next); then compound 3. At a limit, below all of these: compound 1.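

In this assay, the step of a 1.5-fold lower number from compound 2 to compound 4 (0.17 log units; within the scatter) shows that, for this pair, the phenyl is not required for the activity seen: with propyl in its place on the saturated chain carbon, the two compounds cannot be told apart. Among the compounds shown here, all earlier compounds kept the phenyl, so compound 4 is the first reading on how much this group matters, and the answer here is that swapping an aromatic ring of carbon for an open chain of fewer heavy atoms leaves no readable difference. Nothing measured here gives a reason for this result.

As far as these compounds go, whether a longer chain, a cyclohexyl ring or a carboxylic acid in place of the propyl would read the same stays open. Also open, from the compounds shown here alone, is whether methyl on the nitrogen, as in compound 3, would act on compound 4 as it does on compound 2.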